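The source may hold more compounds than are shown below. What is called first, only, known or untested is meant among the compounds shown, and "the series" means these compounds.

Within the data shown here, compound 1 `CC(NC(=O)COc1cc(C(F)(F)F)c2c(-c3ccccc3)nn(C)c2n1)c1ccccn1` has the highest of the three numbers measured so far. In a functional assay on isolated protein for antagonist activity at Orexin/Hypocretin receptor type 1 (Homo sapiens), read by fluorescence, FLIPR and calcium flux, with a stated time of 1 h (a lower number here means a stronger inhibitor, a higher number a weaker inhibitor), compound 1 gives 2670 nM, while compound 2 `C[C@H](NC(=O)COc1cc(C(F)(F)F)c2c(-c3ccccc3)n[nH]c2n1)c1ccccc1` gives 200 nM and compound 3 `C[C@H](NC(=O)CNc1cc(C(F)(F)F)c2c(-c3ccccc3)nn(C)c2n1)c1ccccc1` gives 357 nM in this assay; both of these gaps lie beyond the usual scatter, so compound 1 is the weakest inhibitor of the three. The unmeasured compound 4 `Cc1nn(C)c(C)c1[C@H](C)NC(=O)COc1cc(C(F)(F)F)c2c(-c3ccccc3)nn(C)c2n1` differs from compound 1 in one place: 1-(1,3,5-trimethyl-1H-pyrazol-4-yl)ethyl in place of 1-(pyridin-2-yl)ethyl on an amide-type nitrogen. Among the measured compounds shown here, no measured pair shows this exact change, so the direction can only be judged from the other two amides, which carry a different group on the same nitrogen and give lower numbers. A step toward a stronger inhibitor, beyond the scatter, is expected from compound 1 to compound 4, namely a 3.8-fold lower number from compound 1 to compound 4 (0.58 log units; beyond the scatter). Compound 4 is therefore estimated at 700 nM in this assay, within a range from 150 nM to 3000 nM.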

Compound 4, inhibition constant: 7 nM
Compound 4: middle estimate off by 100-fold (2.00 log units), on the high side, outside the stated range (below it).
By their numbers in this assay, from the lowest: compound 4; then compounds 2 and 3 (each within the scatter of the next); then compound 1.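

At the amide-type nitrogen, the choice of group alone can shift the result greatly in this assay: 1-(1,3,5-trimethyl-1H-pyrazol-4-yl)ethyl in place of 1-(pyridin-2-yl)ethyl gives a 380-fold lower number from compound 1 to compound 4 (2.58 log units; beyond the scatter), with the rest of the molecule unchanged. The earlier compounds shown here could not show this, since no two of them differed in only one place. Nothing shown here explains the size of this step.

The step also brings a defined stereocentre, so the contributions of the ring and of the stereocentre remain unseparated. A 1-(1H-pyrazol-4-yl)ethyl group without the three methyl groups would show how much of the step depends on those methyls.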